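The compounds below may be only part of what the source reports. "The series", "measured", "known", "first", "only" and "open" are said of these compounds alone.

Three analogues of the shared core have numbers in a functional assay with Alpha-1A adrenergic receptor (Homo sapiens) as the target, read by calcium flux; a higher number here means a larger maximal response, a lower number a smaller maximal response. Compound 1 `Cn1nccc1-c1ccccc1NCC1=NCCN1` gives 108% and compound 2 `CCn1cccc1-c1ccccc1NCC1=NCCN1` gives 93%. Compound 3 `c1ccc(-c2nc[nH]n2)c(NCC2=NCCN2)c1` gives 135%, the highest of the three, its gaps to compound 1 and compound 2 both beyond the scatter. Compound 4 `c1ccc(-c2cn[nH]c2)c(NCC2=NCCN2)c1` differs from compound 3 by 1H-pyrazol-4-yl in place of 1H-1,2,4-triazol-3-yl on an aromatic carbon. Within the data shown here, only one measured step bears on this move, the exchange of one five-membered ring for another on the same aromatic carbon, a number 27 percentage points higher from compound 1 to compound 3 (beyond the scatter), a modest rise. Since that rise attached to the 1H-1,2,4-triazol-3-yl ring which now leaves, part of it is expected to be given back, so compound 4 is expected to show a modest drop, a number 20 percentage points lower from compound 3 to compound 4 (beyond the scatter). Compound 4 is estimated at 115%, within 90% to 140%.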

Compound 4, largest response reached (reported as maximal response), in percent of the reference or control that the assay uses: 112%
Compound 4: the middle estimate sits 3 percentage points above what was measured, within the range that was stated.
By their numbers in this assay, from the lowest: compound 2; then compounds 1 and 4 (each within the scatter of the next); then compound 3.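

In this assay the ring on this aromatic carbon matters in the reverse direction too: the exchange gives a number 23 percentage points lower from compound 3 to compound 4 (beyond the scatter) and so the higher response does not carry over to 1H-pyrazol-4-yl. Against 1-methyl-1H-pyrazol-5-yl the same ring gives a number 4 percentage points higher from compound 1 to compound 4 (within the scatter) and so, among these three compounds, the higher response stays with 1H-1,2,4-triazol-3-yl alone. Nothing at hand accounts for this difference between the rings. Open, as far as these compounds go, is whether a tetrazol-5-yl ring, a pyridin-3-yl ring or a simple amine on this carbon reaches the response of compound 3 or falls back towards that of compound 4.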